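Replacing 2,4-dimethoxyphenyl with 4-bromophenyl in compound 3

The source may hold more compounds than are shown below. What is called first, only, known or untested is meant among the compounds shown, and "the series" means these compounds.

Compound 1 `c1ccc(C(c2c[nH]c3ccccc23)c2c[nH]c3ccccc23)cc1`: 21800 nM
Compound 2 `Oc1ccc(C(c2c[nH]c3ccc(Br)cc23)c2c[nH]c3ccc(Br)cc23)cc1`: 4000 nM
Compound 3 `COc1ccc(C(c2c[nH]c3ccc(Br)cc23)c2c[nH]c3ccc(Br)cc23)c(OC)c1`: 63200 nM

In a functional assay on HeLa cells (Homo sapiens) for inhibition, read by MTT assay, with a stated time of 48 h (on this read-out lower numbers stand for stronger inhibition and higher numbers for weaker inhibition), compound 3 has the highest number of the three, at 63200 nM. Compound 4 `Brc1ccc(C(c2c[nH]c3ccc(Br)cc23)c2c[nH]c3ccc(Br)cc23)cc1` carries 4-bromophenyl in place of 2,4-dimethoxyphenyl on a saturated chain carbon bound to two aromatic carbons. Going by the values given here, one measured step bears on this change, a large one at the same place, where 2,4-dimethoxyphenyl replaced 4-hydroxyphenyl: a 16-fold higher number from compound 2 to compound 3 (1.20 log units; beyond the scatter). Removing 2,4-dimethoxyphenyl may therefore lower the number in this assay. Among the compounds with values here, no measured compound shows what 4-bromophenyl does here on the shared core, so a smaller step is expected. The expected change is a 4.0-fold lower number from compound 3 to compound 4 (0.60 log units; beyond the scatter). The estimate for compound 4 is 16000 nM, with an expected range of 5000 nM to 50000 nM.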

Compound 4, half-maximal inhibitory concentration: 1500 nM
Compound 4: middle estimate off by 11-fold (1.03 log units), on the high side; the measured number lies below the stated range.
By their numbers in this assay, from the lowest: compound 4; then compound 2; then compound 1; then compound 3.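

In this assay, the group on this saturated chain carbon turns out to control the number over a wide span: 4-bromophenyl in place of 2,4-dimethoxyphenyl gives a 42-fold lower number from compound 3 to compound 4 (1.62 log units; beyond the scatter) and reaches lower than the hydroxy compound did. A free hydroxy group is thus not required for a low number, as bromo in its place gives a 2.7-fold lower number from compound 2 to compound 4 (0.43 log units; beyond the scatter) on the same core. No measurement shown here explains these differences.

Going by these compounds, whether an amine or a carboxylic acid in place of the bromo of compound 4 would keep the number this low remains open.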